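The source may report more compounds than this note shows. Statements on the series, on what has been measured and on what is new or still open speak of the compounds shown alone.

Working notes on the series

Three compounds have numbers in a functional assay on DU-145 cells (Homo sapiens) for inhibition, read by trypan blue exclusion, with a stated time of 96 h; on this read-out higher numbers stand for weaker inhibition of growth and lower numbers for stronger inhibition of growth. Compound 1 `O=C(/C(=C\OCc1ccccc1)S(=O)(=O)c1ccccc1Cl)c1ccc(Cl)cc1` gives 1000 nM. Compound 2 `O=C(/C(=C\c1ccc(O)cc1O)Sc1ccc(Br)cc1)c1ccc(Cl)cc1` gives 50000 nM, and compound 3 `O=C(/C(=C\c1ccc(O)cc1O)Sc1ccccc1Br)c1ccc(Cl)cc1` gives 50000 nM. Compound 2 is level with compound 3 at the digits shown, the two together standing at the highest number of the three; compound 1 sits at a far lower number, a gap beyond the scatter. Within the data shown here, the only single-point step so far, no change at the digits printed from compound 2 to compound 3 (within the scatter), changes the aryl on the sulfur and stays within the scatter.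

Compound 4 `O=C(/C(=C\c1c(O)cc(O)cc1O)Sc1ccc(Br)cc1)c1ccc(Cl)cc1` differs from compound 2 by hydroxy in place of hydrogen on an aromatic carbon. Among the measured compounds shown here, no measured step touches the benzylidene ring, so no step bears directly on this change; the one step that exists, on the sulfur aryl, shows the high end of the series is tolerant of variation. The expectation is therefore no change beyond the scatter, and compound 4 is estimated at 50000 nM (range 20000 nM to 100000 nM), a step of no change at the digits printed from compound 2 to compound 4 (within the scatter).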

Compound 4, concentration for 50% growth inhibition: 50000 nM
Estimate against measurement, compound 4: no gap at the digits printed, and the stated range covers the measured number.
By their numbers in this assay, from the lowest: compound 1; then compounds 2, 3 and 4 (each within the scatter of the next).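

In this assay, among these compounds, the change from 2,4-dihydroxyphenyl to 2,4,6-trihydroxyphenyl reads no change at the digits printed from compound 2 to compound 4 (within the scatter) and gives the first measured step on this ring, where earlier only the aryl on the sulfur had been varied. A hydroxy at this place, ortho to a large group and meta to two hydroxy groups, leaves the number where it stood, but this is seen only at the high end of the numbers shown. No measurement in hand accounts for this flat step.

As far as these compounds go, whether a methoxy, an amine or a carboxylic acid at this place would give the same result remains open, as does the outcome of this hydroxy change alongside the 2-bromophenyl of compound 3. Compound 1 differs from these compounds in more than one place, so no single change yet accounts for its far lower number.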